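The compounds below may be only part of what the source reports. "The series", "measured", "known", "first", "only" and "open" are said of these compounds alone.

Compound 1 `Cc1c2c(nn1-c1nnc(-c3ccc(OC(C)C)c(C#N)c3)s1)CCN(CCC(=O)O)C2` gives 2.76 in a physicochemical assay for lipophilicity, at pH 7.4; a higher number here means a more lipophilic compound, a lower number a more polar compound.
Compound 2 `CC(C)Oc1ccc(-c2nnc(-c3ccnn3C)s2)cc1Cl` gives 7.04 in this assay.
Compound 3 `CC(C)Oc1ccc(-c2nnc(-n3ncc4c3CCN(CCC(=O)O)C4)s2)cc1Cl` gives 3.54 in this assay.

Among the three numbers, compound 2 stands highest in this assay. Compound 3 lies nearest, lower by an amount beyond the scatter, and compound 1 lies furthest, lower by a still larger amount, also beyond the scatter. Within the data shown here, no two of the measured compounds differ in only one place, so no single-change step is available to lean on.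

Compound 4 `Cc1[nH]ncc1-c1nnc(-c2ccc(OC(C)C)c(Cl)c2)s1` has not yet been measured in this assay. It differs from compound 2 in one place, the two having the same atoms joined differently: 5-methyl-1H-pyrazol-4-yl in place of 1-methyl-1H-pyrazol-5-yl on an aromatic carbon The expectation therefore rests on compound 2 and the counted difference alone. The step from compound 2 to compound 4 in this assay is expected to be downward and modest, a number 0.54 log units lower from compound 2 to compound 4 (beyond the scatter), beyond the scatter but not by much. For compound 4 the estimate in this assay is 6.5, within a range from 5.9 to 7.1.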

Compound 4, distribution coefficient: 5.45
Estimate against measurement, compound 4: 1.05 log units above, and the stated range ends above it.
By their numbers in this assay, from the lowest: compound 1; then compound 3; then compound 4; then compound 2.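

In this assay, putting 5-methyl-1H-pyrazol-4-yl in place of 1-methyl-1H-pyrazol-5-yl on this aromatic carbon gives a large step, a number 1.59 log units lower from compound 2 to compound 4 (beyond the scatter), even though the two groups have the same atoms, joined differently. It is the only single-change step shown, and it establishes that at this position the read-out can move substantially without any change in the heavy atoms. The entering group counts 1 hydrogen-bond donor and 1 hydrogen-bond acceptor, the leaving group 0 hydrogen-bond donors and 2 hydrogen-bond acceptors, but no measurement here accounts for the size of the step.

Going by these compounds, it remains open whether the step follows the hydrogen on the ring nitrogen or the changed attachment, which a 1-methyl-1H-pyrazol-4-yl group at this position could help separate. Also open, on these data alone, is whether a step of this size would recur in compounds carrying a carboxylic acid.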